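Moving the ring nitrogen on a pyridinylmethyl arm

The source may report more compounds than this note shows. Statements on the series, on what has been measured and on what is new or still open speak of the compounds shown alone.

Of the compounds shown here, two sharing one core have been tested in an assay on isolated protein for inhibition of Gonadotropin-releasing hormone receptor (Homo sapiens); a lower number here means a stronger inhibitor, a higher number a weaker inhibitor. Compound 1, `CCCn1c(SCc2cc([N+](=O)[O-])ccc2OC)nc2cc(NC(=O)NC(C)(C)C)ccc21`, gives 18 nM in this assay. Compound 2, `COc1ccc([N+](=O)[O-])cc1CSc1nc2cc(NC(=O)NC(C)(C)C)ccc2n1Cc1ccccn1`, gives 43 nM. Within the data shown here, the only change between them is pyridin-2-yl in place of ethyl on a saturated chain carbon bound to an aromatic nitrogen, and it brought a 2.4-fold higher number from compound 1 to compound 2 (0.38 log units; beyond the scatter). Compound 2 therefore stands with the higher of the two numbers seen so far, its nearest neighbour being compound 1.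

Compound 3, `COc1ccc([N+](=O)[O-])cc1CSc1nc2cc(NC(=O)NC(C)(C)C)ccc2n1Cc1cccnc1`, is the next compound in line. Its difference from compound 2 is pyridin-3-yl in place of pyridin-2-yl on a saturated chain carbon bound to an aromatic nitrogen. Among the measured compounds shown here, no measured step covers a change of this kind: the one step seen so far swapped a chain for a ring, whereas here the ring stays and only the position of its nitrogen shifts. With nothing to point in either direction, the expectation for compound 3 is a number close to that of compound 2, estimated as 50 nM with a range from 18 nM to 140 nM, which amounts to an expected step of a 1.2-fold higher number from compound 2 to compound 3 (0.07 log units; within the scatter), not beyond the scatter.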

Compound 3, half-maximal inhibitory concentration: 33 nM
Estimate against measurement, compound 3: 1.5-fold (0.18 log units) above, and the stated range covers the measured number.
By their numbers in this assay, from the lowest: compounds 1, 3 and 2 (each within the scatter of the next, the first and the last beyond it).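

Shifting the ring nitrogen turns out to be a small change at this carbon: in this assay the swap of pyridin-2-yl for pyridin-3-yl gives a 1.3-fold lower number from compound 2 to compound 3 (0.11 log units; within the scatter) and so cannot be told apart from repeat-measurement noise. The comparison with the ethyl end of the propyl chain also reads differently for this ring, since pyridin-3-yl in place of ethyl gives a 1.8-fold higher number from compound 1 to compound 3 (0.26 log units; within the scatter) while pyridin-2-yl in its place gave a 2.4-fold higher number from compound 1 to compound 2 (0.38 log units; beyond the scatter), yet with the two pyridine compounds themselves within the scatter of each other, this contrast is too slight to rank the two ring positions. Nothing available accounts for these small differences, so the numbers describe the change without explaining it.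

From the compounds shown here alone, whether the ring nitrogen matters at all remains open, as a plain phenyl ring on the same saturated chain carbon would be needed to answer that. It is equally unknown how this position would respond to an amine or a carboxylic acid at the end of a longer chain, which would test far more than the small swaps seen here.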